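Chloro to fluoro on the aryl ring of compound 2

This account rests on a few compounds, and the source may have more. Where it says the series, first, only, none or still open, it means among the compounds named here.

Three members of this series have been run in a functional assay, with a stated time of 10 min; a higher number here means a weaker inhibitor, a lower number a stronger inhibitor. Compound 1 `Cn1c(NN)nc(-c2ccccc2O)c(C#N)c1=O` gives 30 ug/mL, compound 2 `Cn1c(NN)nc(-c2ccccc2Cl)c(C#N)c1=O` gives 46 ug/mL, and compound 3 `CSc1nc(-c2ccccc2Cl)c(C#N)c(=O)n1C` gives 67 ug/mL. Compound 2 holds the second highest of the three numbers; its nearest neighbour is compound 3, reached by a 1.5-fold higher number from compound 2 to compound 3 (0.16 log units; within the scatter), and its furthest is compound 1, from which it is reached by a 1.5-fold higher number from compound 1 to compound 2 (0.19 log units; within the scatter). All three numbers sit inside the usual spread of repeat measurements.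

Compound 4 `Cn1c(NN)nc(-c2ccccc2F)c(C#N)c1=O` is not yet measured. It differs from compound 2 by fluoro in place of chloro on an aromatic carbon. Within the data shown here, the one measured step that bears on this change is the substituent exchange at the same aromatic carbon, a 1.5-fold higher number from compound 1 to compound 2 (0.19 log units; within the scatter), which stayed within the scatter. On that basis no step beyond the scatter is expected in this assay, in either direction, so the step from compound 2 to compound 4 is estimated as no change at the digits printed from compound 2 to compound 4 (within the scatter). Compound 4 is therefore expected to give about 46 ug/mL, with a range from 23 ug/mL to 92 ug/mL.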

Compound 4, half-maximal inhibitory concentration: 49 ug/mL
Compound 4: middle estimate off by 1.1-fold (0.03 log units), on the low side; the measured number falls inside the stated range.
By their numbers in this assay, from the lowest: compounds 1, 2, 4 and 3 (each within the scatter of the next, the first and the last beyond it).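

At the aromatic carbon ortho to a large group, this assay now gives a direct comparison of two halogens: fluoro in place of chloro gives a 1.1-fold higher number from compound 2 to compound 4 (0.03 log units; within the scatter). Fluoro in place of hydroxy gives a 1.6-fold higher number from compound 1 to compound 4 (0.21 log units; within the scatter), so hydroxy, chloro and fluoro at this carbon, on an otherwise identical compound, all give numbers within the scatter of one another. No measurement here bears on why these three substituents read alike.

Open, going by these compounds, is whether this flat reading extends to a methoxy, an amine or a carboxylic acid at the same carbon, any of which would test the position with a group unlike these three. Also open, on these data alone, is whether fluoro in place of chloro reads the same with methylsulfanyl in place of aminoamino, as in compound 3.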